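This account rests on a few compounds, and the source may have more. Where it says the series, first, only, none or still open, it means among the compounds named here.

Measured values, from a functional assay on SMMC-7721 cells (Homo sapiens) for antiproliferative activity, read by MTT assay, with a stated time of 48 h; a lower number here means a stronger inhibitor, a higher number a weaker inhibitor
Compound 1 `CC(=O)O[C@]1(C)/C=C/C(=O)/C(CO)=C\C[C@](C)(CCC=C(C)C)/C=C/[C@H]1OC(=O)C=C(C)C` - 3080 nM
Compound 2 `CC(C)=CCC[C@](C)(/C=C/[C@@H](OC(=O)C=C(C)C)[C@](C)(O)/C=C/C(=O)/C=C/N(C)C)CC=O` - 10300 nM

Compound 2 (10300 nM) has the higher number of the two and is the weaker inhibitor. Compound 1 (3080 nM) lies lower, a gap beyond the scatter. Compound 3 `CC(C)=CCC[C@](C)(/C=C/[C@@H](OC(=O)C=C(C)C)[C@](C)(O)/C=C/C(=O)/C=C/N1CCN(C)CC1)CC=O` differs from compound 2 in one place (4-methylpiperazin-1-yl in place of dimethylamino on a double-bonded chain carbon bound to a double-bonded chain carbon). Going by the values given here, no measured pair shows this exchange, so the expectation rests on compound 2 (10300 nM) alone. The step (a 1.3-fold lower number from compound 2 to compound 3 (0.11 log units; within the scatter)) is expected to stay within the scatter in this assay, with no clear direction. For compound 3 the estimated value is 8000 nM, with an expected range from 3000 nM to 20000 nM.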

Compound 3, half-maximal inhibitory concentration: 3090 nM
Compound 3: middle estimate off by 2.6-fold (0.41 log units), on the high side; low and high end bracket the measured number.
By their numbers in this assay, from the lowest: compounds 1 and 3 (each within the scatter of the next); then compound 2.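

In this assay, 4-methylpiperazin-1-yl in place of dimethylamino on a double-bonded chain carbon bound to a double-bonded chain carbon gives a 3.3-fold lower number from compound 2 to compound 3 (0.52 log units; beyond the scatter). This position therefore responds to the amine it carries, and the ring-bearing group is tolerated there, which compound 2 alone could not show. No measurement at hand bears on the reason for this step. Still open, on these data alone, is whether the step follows the ring or its second nitrogen. Piperidin-1-yl or morpholin-4-yl at the same place would separate the two.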